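Bromo to hydrogen on compound 2

The source may hold more compounds than are shown below. What is called first, only, known or untested is meant among the compounds shown, and "the series" means these compounds.

In a functional assay on A549 cells (Homo sapiens) for antiproliferative activity, read by MTT assay, with a stated time of 48 h (a lower number here means a stronger inhibitor, a higher number a weaker inhibitor), compound 2 (`COc1ccc(/C=C/c2cc(OC)cc(OC)c2/C=C/C(=O)c2ccc(Br)cc2)cc1`) gives 8.3 ug/mL and compound 1 (`COc1ccc(/C=C/c2cc(OC)cc(OC)c2/C=C/C(=O)c2ccc(Cl)c(Cl)c2)cc1`) gives 5.9 ug/mL, so the two lie within the scatter of each other. Compound 3 (`COc1ccc(/C=C/c2cc(OC)cc(OC)c2/C=C/C(=O)c2ccccc2)cc1`) carries hydrogen in place of bromo on an aromatic carbon, para to a large group: hydrogen in place of bromo on an aromatic carbon. Going by the values given here, no compound without a halogen has been measured yet. Among the compounds with values here, the one measured step that bears on this change is a 1.4-fold higher number from compound 1 to compound 2 (0.15 log units; within the scatter), which stays within the scatter, so no step beyond the scatter is expected in this assay. The expected step is a 1.2-fold higher number from compound 2 to compound 3 (0.08 log units; within the scatter). Compound 3 is estimated at 10 ug/mL, with an expected range of 5 ug/mL to 22 ug/mL.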

Compound 3, half-maximal inhibitory concentration: 3.9 ug/mL
For compound 3 the middle estimate is 2.6-fold (0.41 log units) above the measured one; measured number outside the range, below it.
By their numbers in this assay, from the lowest: compounds 3, 1 and 2 (each within the scatter of the next, the first and the last beyond it).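

In this assay, hydrogen in place of bromo on this aromatic carbon gives a 2.1-fold lower number from compound 2 to compound 3 (0.33 log units; beyond the scatter), a modest step and the only one so far beyond the scatter, so among these compounds activity does not depend on bromo here. Phenyl in place of 3,4-dichlorophenyl gives a 1.5-fold lower number from compound 1 to compound 3 (0.18 log units; within the scatter), so the compounds shown do not separate these two groups. No measurement shown accounts for the bromo step. Open, from the compounds shown here alone, is whether an amine or a carboxylic acid on this aromatic carbon would stay level with hydrogen or fall nearer bromo.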